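The source may hold more compounds than are shown below. What is called first, only, known or untested is meant among the compounds shown, and "the series" means these compounds.

In a functional assay on HepG2 cells (Homo sapiens) for inhibition, read by MTT assay, with a stated time of 72 h (on this read-out lower numbers stand for stronger inhibition and higher numbers for weaker inhibition), compound 1 `CC(C)(C)n1cc2c(n1)C(=O)CC1(CCN(C(=O)c3cc(-c4ccccc4Cl)nc4ccccc34)CC1)O2` gives > 10000 nM, which is a limit of the assay and not a number. Compound 2 `CN(C)c1ccc(-c2cc(C(=O)N3CCC4(CC3)CC(=O)c3nn(C(C)(C)C)cc3O4)c3ccccc3n2)cc1` gives 1730 nM, and compound 3 `CC(C)(C)n1cc2c(n1)C(=O)CC1(CCN(C(=O)c3cc(-c4ccccn4)nc4ccccc34)CC1)O2` gives 1500 nM. These two values sit close together, with a 1.2-fold lower number from compound 2 to compound 3 (0.06 log units; within the scatter). Compound 4 `CC(C)Oc1cc(C(=O)N2CCC3(CC2)CC(=O)c2nn(C(C)(C)C)cc2O3)c2ccccc2n1` differs from compound 3 on one aromatic carbon, where isopropoxy replaces pyridin-2-yl: isopropoxy in place of pyridin-2-yl on an aromatic carbon. Earlier swaps at this carbon gave an at least 5.7-fold lower number from compound 1 to compound 2 (0.76 log units; beyond the scatter) and an at least 6.6-fold lower number from compound 1 to compound 3 (0.82 log units; beyond the scatter), so this place can move the number. However, all three measured compounds carry a ring there, whereas isopropoxy has none, so the direction is uncertain. A modest rise is expected in this assay, and the expected change is a 2.0-fold higher number from compound 3 to compound 4 (0.30 log units; within the scatter). For compound 4 the estimated value is 3000 nM, with an expected range of 800 nM to 10000 nM.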

Compound 4, half-maximal inhibitory concentration: 3150 nM
Estimate against measurement, compound 4: 1.1-fold (0.02 log units) below, and the stated range covers the measured number.
By their numbers in this assay, from the lowest: compounds 3, 2 and 4 (each within the scatter of the next, the first and the last beyond it). At a limit, above all of these: compound 1.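

Isopropoxy, the only group here without a ring, still gives a measured number at this aromatic carbon, with a 2.1-fold higher number from compound 3 to compound 4 (0.32 log units; beyond the scatter) and a 1.8-fold higher number from compound 2 to compound 4 (0.26 log units; within the scatter). So a ring at this carbon is not needed for a measured number, though only the first of these steps lies beyond the scatter. Compound 1 stands at a limit and not a number, yet the step of an at least 3.1-fold lower number from compound 1 to compound 4 (0.50 log units; beyond the scatter) shows that carrying a ring does not by itself give the lower number: the limit of > 10000 nM in this assay, at which 1 of the 4 values shown sits.

The compounds shown leave open how an amine or a longer alkoxy chain would behave at this carbon.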